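The source may hold more compounds than are shown below. What is called first, only, known or untested is meant among the compounds shown, and "the series" means these compounds.

Working notes on the series.

Of the compounds shown here, three of the shared core have been read in a functional assay on CHO cells for positive allosteric modulation of metabotropic glutamate receptor 2 (Homo sapiens), read by GTPgammaS binding, with a stated time of 30 min; a lower number here means a smaller maximal response, a higher number a larger maximal response. Compound 1 `N#Cc1c(N2CCC(c3ccccc3)CC2)ccn2c(CC(F)(F)F)nnc12` gives 277%. Compound 2 `N#Cc1c(N2CCC(c3ccccc3)CC2)ccn2c(CC3CC3)nnc12` gives 278%, and the step of a number 1 percentage points higher from compound 1 to compound 2 (within the scatter) shows that swapping these two groups on this core leaves the maximal response unchanged for practical purposes. Compound 3 `FC(F)(F)Cc1nnc2c(Cl)c(N3CCC(c4ccccc4)CC3)ccn12` gives 300%, the highest of the three numbers: the step of a number 23 percentage points higher from compound 1 to compound 3 (beyond the scatter) is beyond the scatter, and the values of compound 2 at 278% and compound 3 at 300% also lie apart by more than the scatter. Compound 3 therefore stands alone at the top of what has been measured.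

Compound 4 `Clc1c(N2CCC(c3ccccc3)CC2)ccn2c(CC3CC3)nnc12` is the next member. Relative to compound 3 it carries cyclopropyl in place of trifluoromethyl on a saturated chain carbon bound to an aromatic carbon. Within the data shown here, the one measured step that bears on this change is a number 1 percentage points higher from compound 1 to compound 2 (within the scatter), made on the cyano-bearing core, and it stayed within the scatter. Among the measured compounds shown here, nothing measured so far suggests the chloro-bearing core should respond differently to the same swap, though only one such comparison exists. The expected step is therefore no change at the digits printed from compound 3 to compound 4 (within the scatter), that is, none beyond the scatter. Compound 4 is estimated to give 300% in this assay, in the range 270% to 330%.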

Compound 4, largest response reached (Emax), in percent of the reference or control that the assay uses: 343%
The estimate for compound 4 lay 43 percentage points below the measured number; the whole stated range lies below it.
By their numbers in this assay, from the lowest: compounds 1 and 2 (each within the scatter of the next); then compound 3; then compound 4.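

In this assay, the swap of 2,2,2-trifluoroethyl to cyclopropylmethyl is not silent on every core: with chloro on the aromatic carbon the step is a number 43 percentage points higher from compound 3 to compound 4 (beyond the scatter), so the outcome of this change depends on the group at the other place: the same change on two cores in this assay, a number 1 percentage points higher (within the scatter) from compound 1 to compound 2 and a number 43 percentage points higher (beyond the scatter) from compound 3 to compound 4, 42 percentage points apart, beyond the scatter of two such steps

Read from the other place, chloro in place of cyano on an aromatic carbon carries more weight when cyclopropylmethyl is present, with a step of a number 65 percentage points higher from compound 2 to compound 4 (beyond the scatter), so its size also depends on its partner: the same change on two cores in this assay, a number 23 percentage points higher (beyond the scatter) from compound 1 to compound 3 and a number 65 percentage points higher (beyond the scatter) from compound 2 to compound 4, 42 percentage points apart, beyond the scatter of two such steps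

The two changes therefore do not act independently in this set, and a step read on the cyano-bearing core cannot be carried over to the chloro-bearing core at face value.

This dependence rests on a single set of four compounds, which leaves open whether it extends to other groups on the aromatic carbon, such as bromo or methyl. On these data alone, it is equally open whether a longer chain, such as n-propyl, or an ether such as methoxymethyl in place of cyclopropylmethyl would follow the same pattern on the chloro-bearing core.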